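Chloro to Hydrogen on the Pendant Phenyl Ring

This account rests on a few compounds, and the source may have more. Where it says the series, first, only, none or still open, it means among the compounds named here.

Measured in a functional assay on the whole organism for inhibition, with Rattus norvegicus as the target, at a dose of 30 mg/kg; a lower number here means less inhibition, a higher number more inhibition at the dose given (going by the name of the read-out):
Compound 1, `Clc1ccccc1-c1nc2ncccc2o1`: 38%
Compound 2, `O=[N+]([O-])c1ccc(-c2nc3cccnc3o2)cc1`: 5%
Compound 3, `O=[N+]([O-])c1ccccc1-c1nc2cccnc2o1`: 57%

Compound 1 stands second of the three in this assay. Compound 3 gives a higher number than compound 1, beyond the scatter, and compound 2 gives a lower number than compound 1, also beyond the scatter. Compound 4, `c1ccc(-c2nc3ncccc3o2)cc1`, differs from compound 1 by one change: hydrogen in place of chloro on an aromatic carbon. For the measured compounds named here, no directly comparable step between measured compounds is available, so the effect of this change is unknown; the only context is that compound 2, the one with the lowest number here, is the one with its substituent not ortho to a group of 9 heavy atoms. The account therefore expects a modest loss in this assay for compound 4, perhaps a number 16 percentage points lower from compound 1 to compound 4 (beyond the scatter), because compound 1 itself gives 38% with the chloro present. Compound 4 is estimated at 22%, within 5% to 42%.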

Compound 4, a percentage reported as inhibition, in the whole organism at one dose (the size of the read-out at that dose, not a potency): 41%
The estimate for compound 4 lay 19 percentage points below the measured number; low and high end bracket the measured number.
By their numbers in this assay, from the lowest: compound 2; then compounds 1 and 4 (each within the scatter of the next); then compound 3.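

In this assay hydrogen in place of chloro on an aromatic carbon, ortho to a group of 9 heavy atoms, gives a number 3 percentage points higher from compound 1 to compound 4 (within the scatter) and so shows that this compound keeps its inhibition at this dose without the chloro. The earlier compounds shown here offered no direct reading of this change. Nothing measured here explains the result.

From the compounds shown here alone, whether an amine or a carboxylic acid at this place would leave the number unchanged stays open. So does whether the same exchange would read alike on a different core.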